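This account rests on a few compounds, and the source may have more. Where it says the series, first, only, none or still open, it means among the compounds named here.

Compounds measured in an ADME assay on cells (Peritoneal macrophage, Mus musculus, strain Balb/c) for cytotoxicity, read by resazurin assay, with a stated time of 72 h (on this read-out higher numbers stand for lower toxicity in this test and lower numbers for higher toxicity in this test), so far:
compound 1 `CC1(Cc2ccc(C(F)(F)F)cc2)CC(S(=O)(=O)c2ccc(F)cc2)=C(c2ccc(/C(N)=N/O)cc2)O1`, 103000 nM
compound 2 `CC1(Cc2ccccc2C(F)(F)F)CC(S(=O)(=O)c2ccc(F)cc2)=C(c2ccc(/C(N)=N/O)cc2)O1`, 105000 nM
compound 3 `COc1cc(CC2(C)CC(S(=O)(=O)c3ccc(F)cc3)=C(c3ccc(/C(N)=N/O)cc3)O2)cc(OC)c1OC`, 92300 nM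

Compound 1 stands second highest of the three, with compound 2 nearest and compound 3 furthest; all three sit within the scatter of one another. The two measured steps that change the group on the saturated chain carbon bound to a saturated ring carbon, a 1.0-fold higher number from compound 1 to compound 2 (0.01 log units; within the scatter) and a 1.1-fold lower number from compound 1 to compound 3 (0.05 log units; within the scatter), show no movement beyond the scatter.

Compound 4 `Cc1ccc(CC2(C)CC(S(=O)(=O)c3ccc(F)cc3)=C(c3ccc(/C(N)=N/O)cc3)O2)cc1` differs from compound 1 by methyl in place of trifluoromethyl on an aromatic carbon. This change lies at the same part of the shared core as the two measured steps, both of which were flat. No step beyond the scatter is therefore expected in this assay; compound 4 is estimated at 100000 nM (range 60000 nM to 170000 nM), the expected step being a 1.0-fold lower number from compound 1 to compound 4 (0.01 log units; within the scatter).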

Compound 4, half-maximal cytotoxic concentration: 54400 nM
Compound 4: middle estimate off by 1.8-fold (0.26 log units), on the high side; the whole stated range lies above it.
By their numbers in this assay, from the lowest: compounds 4, 3, 1 and 2 (each within the scatter of the next).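

In this assay, methyl in place of trifluoromethyl on the aromatic carbon gives a 1.9-fold lower number from compound 1 to compound 4 (0.28 log units; within the scatter), so this position still shows no step beyond the scatter, even with a fluorine-free group. The wider swaps of the whole substituted phenyl group agree: a 1.7-fold lower number from compound 3 to compound 4 (0.23 log units; within the scatter) and a 1.9-fold lower number from compound 2 to compound 4 (0.29 log units; within the scatter). Nothing available explains these steps.

Open, as far as these compounds go, is whether an amine, a carboxylic acid or a longer chain on this aromatic carbon would move the number beyond the scatter. Changes elsewhere on the shared core also remain open.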